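Three macrocycles at the limit, and a fourth to come

The source may report more compounds than this note shows. Statements on the series, on what has been measured and on what is new or still open speak of the compounds shown alone.

Compound 1 `CCOc1ccc2c(c1)NC(=O)Nc1cnc(C#N)c(n1)OCC/C=C\CO2`: > 10000 nM, a limit
Compound 2 `Cc1ccc2c(c1)NC(=O)Nc1cnc(C#N)c(n1)OCC/C=C\CO2`: > 10000 nM, a limit
Compound 3 `N#Cc1ncc2nc1OCC/C=C\COc1ccc(CCCOC3CCCCO3)cc1NC(=O)N2`: > 10000 nM, a limit

All three results come from a functional assay on NCI-H1299 cells (Homo sapiens), read by flow cytometry (a lower number here means that less compound is needed, a higher number that more compound is needed for the effect), and none of them is a number: each is the limit of > 10000 nM in this assay, at which 3 of the 3 values shown sit. Compound 3 therefore has no measured value, and its > 10000 nM is only a limit.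

Compound 4 `N#Cc1ncc2nc1OCC/C=C\COc1ccc(OCCOC3CCCCO3)cc1NC(=O)N2` changes one group of compound 3: 2-((oxan-2-yl)oxy)ethoxy in place of 3-((oxan-2-yl)oxy)propyl on an aromatic carbon. On the same aromatic carbon, 2-((oxan-2-yl)oxy)ethoxy stands in place of 3-((oxan-2-yl)oxy)propyl. Among the compounds with values here, three measured steps bear on this change: a step that the two limits leave unreadable from compound 1 to compound 3, a step that the two limits leave unreadable from compound 2 to compound 3 and a step that the two limits leave unreadable from compound 1 to compound 2. None of them has a readable size, so they offer no measured size or direction to carry over. Compound 1, with ethoxy on that carbon, also gives only a limit at > 10000 nM.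

Within the data shown here, no step of known size or direction is expected in this assay, and another limit is the likeliest report. The expected outcome is a step that the limit leaves unreadable from compound 3 to compound 4. For compound 4 the estimate is 12000 nM, with an expected range of 4000 nM to 30000 nM.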

Compound 4, half-maximal effective concentration: > 10000 nM
Compound 4 was reported as a limit (the forecaster's own chance of this, stated with the estimate: 85%); the middle value is on the limit's open side.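

Compound 4, like compound 1, compound 2 and compound 3, is reported only as a limit, so no step among these four can be read: the limit of > 10000 nM in this assay, at which 4 of the 4 values shown sit.

The compounds shown leave open whether any group on that aromatic carbon gives a measured value in this assay.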